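Chain extension from compound 2 to compound 4

This account rests on a few compounds, and the source may have more. Where it says the series, first, only, none or still open, it means among the compounds named here.

In a functional assay on HL-60 cells (Homo sapiens) for cytotoxicity, read by MTT assay, with a stated time of 48 h (a lower number here means a stronger inhibitor, a higher number a weaker inhibitor), compound 1 `CCCCCCCCCC(=O)N[C@H](C(=O)Nc1ccn([C@H]2O[C@@H](CO)[C@H](O)[C@H]2O)c(=O)n1)C(C)C` gives 2040 nM and compound 3 `CCCCCCCCCC(=O)N[C@@H](CCSC)C(=O)Nc1ccn([C@H]2O[C@@H](CO)[C@H](O)[C@H]2O)c(=O)n1` gives 280 nM. Compound 2 `CCCCCCCCCC(=O)N[C@@H](CCCNC(=N)N)C(=O)Nc1ccn([C@H]2O[C@@H](CO)[C@H](O)[C@H]2O)c(=O)n1` gives 584 nM, the second highest of the three numbers. Compound 4 `CCCCCCCCCCCCCC(=O)N[C@@H](CCCNC(=N)N)C(=O)Nc1ccn([C@H]2O[C@@H](CO)[C@H](O)[C@H]2O)c(=O)n1` differs from compound 2 by butyl in place of hydrogen on a saturated chain carbon, nine bonds along the chain from a carbonyl carbon.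

Among the compounds with values here, none of the measured steps touches this chain. All three change a different group, on or along the saturated chain carbon bound to an amide-type nitrogen and a carbonyl carbon. Their sizes, a 3.5-fold lower number from compound 1 to compound 2 (0.54 log units; beyond the scatter), a 7.3-fold lower number from compound 1 to compound 3 (0.86 log units; beyond the scatter) and a 2.1-fold lower number from compound 2 to compound 3 (0.32 log units; beyond the scatter), are all modest and serve only as a rough scale for the series. The data give no direction for a change in chain length, so no step beyond the scatter is expected in this assay, and the expectation stays close to compound 2 at 584 nM. The expected step is a 1.2-fold lower number from compound 2 to compound 4 (0.07 log units; within the scatter). For compound 4, the estimated value is 500 nM, with an expected range of 170 nM to 1500 nM.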

Compound 4, half-maximal inhibitory concentration in the HL-60 assay: 405 nM
The estimate for compound 4 lay 1.2-fold (0.09 log units) above the measured number; the measured number falls inside the stated range.
By their numbers in the HL-60 assay, from the lowest: compounds 3, 4 and 2 (each within the scatter of the next, the first and the last beyond it); then compound 1.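

Butyl in place of hydrogen, on a saturated chain carbon nine bonds along the chain from a carbonyl carbon, is the only change shown on this chain, and in the HL-60 assay it gives a 1.4-fold lower number from compound 2 to compound 4 (0.16 log units; within the scatter). In a physicochemical assay for lipophilicity (on this read-out lower numbers stand for lower lipophilicity and higher numbers for higher lipophilicity), compound 2 gives 0.76 and compound 4 gives 0.45, so the same change gives a number 0.31 log units lower from compound 2 to compound 4 (beyond the scatter). This pair is therefore separated on the partition coefficient alone: the measured partition coefficient of compound 2, 0.76, and of compound 4, 0.45, a number 0.31 log units lower (beyond the scatter)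

The compounds shown leave open whether a longer chain, or an amine or a carboxylic acid on this chain, would shift the number in the HL-60 assay. They also leave open whether butyl in this place gives a similar result when isopropyl, as in compound 1, or 2-(methylsulfanyl)ethyl, as in compound 3, stands on the saturated chain carbon bound to an amide-type nitrogen and a carbonyl carbon.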